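The compounds below may be only part of what the source reports. "The series", "measured", "known", "first", "only" and "open" are said of these compounds alone.

In a functional assay on CCRF-CEM cells (Homo sapiens) for antiproliferative activity, read by cell counting, with a stated time of 96 h (on this read-out lower numbers stand for stronger inhibition and higher numbers for weaker inhibition), compound 1 `CC(=O)c1ccc(Oc2ccccc2NC(C)=C2C(=O)CC(c3ccccc3)CC2=O)cc1` gives 220 nM. Compound 2 `COc1ccc(Oc2ccccc2NC(C)=C2C(=O)CC(c3ccccc3)CC2=O)cc1` gives 120 nM and compound 3 `CC(Nc1ccccc1Oc1ccc(C(C)O)cc1)=C1C(=O)CC(c2ccccc2)CC1=O` gives 120 nM, which places compound 1 within the scatter of both.

Compound 4 `CC(Nc1ccccc1Oc1cccc(N)c1)=C1C(=O)CC(c2ccccc2)CC1=O`, not yet measured, has 3-aminophenyl in place of 4-acetylphenyl on an oxygen on an aromatic ring.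

Among the compounds with values here, three measured steps bear on this change. Replacing the acetyl on an aromatic carbon gave a 1.8-fold lower number from compound 1 to compound 2 (0.26 log units; within the scatter) with methoxy and a 1.8-fold lower number from compound 1 to compound 3 (0.26 log units; within the scatter) with 1-hydroxyethyl. Exchanging those two groups gave no change at the digits printed from compound 2 to compound 3 (within the scatter). Within the data shown here, no measured compound carries an amino group, so the evidence is indirect and the range has to stay wide.

With a 1.8-fold lower number from compound 1 to compound 2 (0.26 log units; within the scatter) and a 1.8-fold lower number from compound 1 to compound 3 (0.26 log units; within the scatter) as the closest precedents, no shift beyond the scatter is expected in this assay. The expected change is a 1.5-fold lower number from compound 1 to compound 4 (0.17 log units; within the scatter). For compound 4 the estimated value is 150 nM, with an expected range from 50 nM to 450 nM.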

Compound 4, half-maximal inhibitory concentration: 42 nM
For compound 4 the middle estimate is 3.6-fold (0.55 log units) above the measured one; the measured number lies below the stated range.
By their numbers in this assay, from the lowest: compound 4; then compounds 2, 3 and 1 (each within the scatter of the next).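

On an oxygen on an aromatic ring, exchanges among 4-acetylphenyl, 4-methoxyphenyl and 4-(1-hydroxyethyl)phenyl stayed within the scatter, whereas 3-aminophenyl moves the number beyond it in this assay (a 5.2-fold lower number from compound 1 to compound 4 (0.72 log units; beyond the scatter); a 2.9-fold lower number from compound 2 to compound 4 (0.46 log units; beyond the scatter); a 2.9-fold lower number from compound 3 to compound 4 (0.46 log units; beyond the scatter)). This position therefore tolerates more than a flat response: compound 4 is the most potent of the four in this read-out, with modest steps to all three others. Nothing available explains this gain.

Compound 4 changes both the group and where it is carried on the phenyl ring, so the contribution of each remains unresolved. 4-Aminophenyl and 3-methoxyphenyl would separate the two, and 3-(dimethylamino)phenyl would test whether the amine hydrogens matter.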